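N-Methylation of the pyrazole and clearance in rat

A few compounds are considered here, and "the series" means these few. Any claim that something is new, unique, unknown or untested is made for them only; others in the source may bear on it.

Measured compounds:
compound 1 `CC(=O)Nc1cc(-c2c(Nc3cc[nH]n3)nc3ccccn23)nc(C)n1`, 38.3 mL/min/kg
compound 2 `CC(=O)Nc1cc(-c2c(Nc3cc[nH]n3)nc3cccnn23)nc(C)n1`, 43.3 mL/min/kg
compound 3 `CC(=O)Nc1cc(-c2c(Nc3ccn(C)n3)nc3ccccn23)nc(C)n1`, 10 mL/min/kg

Of the compounds shown here, three have been measured in an in vivo ADME assay on the whole organism for pharmacokinetics, with Rattus norvegicus as the target, at a dose of 0.5 mg/kg by the intravenous route; a higher number here means faster removal of the compound, a lower number slower removal. Compound 1 `CC(=O)Nc1cc(-c2c(Nc3cc[nH]n3)nc3ccccn23)nc(C)n1` gives 38.3 mL/min/kg. Compound 2 `CC(=O)Nc1cc(-c2c(Nc3cc[nH]n3)nc3cccnn23)nc(C)n1` gives 43.3 mL/min/kg, a value within the usual scatter of that of compound 1; the difference between the two cores of compound 1 and compound 2 is not broken down here. Compound 3 `CC(=O)Nc1cc(-c2c(Nc3ccn(C)n3)nc3ccccn23)nc(C)n1` gives 10 mL/min/kg.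

Among the compounds with values here, the one counted step among the measured compounds is methyl in place of hydrogen on an aromatic nitrogen, which made a 3.8-fold lower number from compound 1 to compound 3 (0.58 log units; beyond the scatter).

Compound 4 `CC(=O)Nc1cc(-c2c(Nc3ccn(C)n3)nc3cccnn23)nc(C)n1` is not yet measured. It differs from compound 2 by methyl in place of hydrogen on an aromatic nitrogen, the same change that led from compound 1 to compound 3, and at the same place in words. The expectation for compound 4 in this assay rests on that single earlier step: because compound 3 gave 10 mL/min/kg after the same change from compound 1, the step from compound 2 to compound 4 is expected to be of a similar size, a 3.6-fold lower number from compound 2 to compound 4 (0.56 log units; beyond the scatter). Within the data shown here, that expectation rests on only one earlier pair, so its range is kept wide. The clearance of compound 4 is estimated at 12 mL/min/kg, with a likely span from 6 mL/min/kg to 25 mL/min/kg.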

Compound 4, clearance: 18.3 mL/min/kg
Estimate against measurement, compound 4: 1.5-fold (0.18 log units) below; the measured number falls inside the stated range.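

In this assay, going from 1H-pyrazol-3-yl to 1-methyl-1H-pyrazol-3-yl on the core of compound 2 gave a 2.4-fold lower number from compound 2 to compound 4 (0.37 log units; beyond the scatter), so the methyl group on the aromatic nitrogen lowered clearance on this core as it had on the core of compound 1. Set side by side, the two steps point the same way and cannot be told apart in size: the same change on two cores in this assay, a 3.8-fold lower number (0.58 log units; beyond the scatter) from compound 1 to compound 3 and a 2.4-fold lower number (0.37 log units; beyond the scatter) from compound 2 to compound 4, 1.6-fold (0.21 log units) apart, within the scatter of two such steps. This shows that the change carried over between these two cores, with neither pair going against it, but two pairs cannot show that it will carry to any further core, that one of these cores responds more than the other, or why clearance falls.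

The compounds shown leave open whether a longer chain on the same ring nitrogen, such as ethyl or a chain ending in an amine, would lower clearance as the methyl group does, or would lose the step. They also leave open whether the step would hold with a group other than the acetamide on the pyrimidine-bearing part of the molecule, such as a free amine.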